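This account rests on a few compounds, and the source may have more. Where it says the series, first, only, none or still open, it means among the compounds named here.

Working notes on the series.

Two members of this series have been run in a functional assay on IMR-32 cells (Homo sapiens) for inhibition, read by sulforhodamine B assay, with a stated time of 48 h, tested at 100 uM; on this read-out higher numbers stand for more inhibition of growth at the one concentration tested and lower numbers for less inhibition of growth. Compound 1, `O=c1c(C2N=C(c3ccccc3)SS2)coc2ccc(Cl)cc12`, is the simpler of the pair, and in this assay compound 1 gives 92%. Compound 2, `O=c1c(C2N=C(c3ccccc3)SS2)coc2cc(Cl)c(F)cc12`, carries a chloro group together with a fluoro group on the same aromatic ring of the shared core, and in this assay compound 2 gives 80%. Compound 2 therefore stands lowest of the two numbers measured, with compound 1 lying above it by a margin that falls beyond the usual scatter of repeated runs.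

Compound 3, `O=c1c(C2N=C(c3ccccc3)SS2)coc2cc(Cl)c(Cl)cc12`, has not yet been measured in this assay. It differs from compound 2 in one place only: chloro in place of fluoro on an aromatic carbon. For the measured compounds named here, no pair of measured compounds differing by exactly this exchange is available, so the direction of the change cannot be read from the two numbers in hand. For the step from compound 2 to compound 3 a small change is expected, a number 5 percentage points higher from compound 2 to compound 3 (within the scatter), most likely within the scatter. In this assay compound 3 is estimated at 85%, within a range of 70% to 95%.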

Compound 3, percent growth inhibition at one concentration: 77%
For compound 3 the middle estimate is 8 percentage points above the measured one; the range from low to high includes it.
By their numbers in this assay, from the lowest: compounds 3 and 2 (each within the scatter of the next); then compound 1.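

In this assay the exchange of fluoro for chloro on this aromatic carbon, ortho to a chloro group, gives a number 3 percentage points lower from compound 2 to compound 3 (within the scatter), so the two halogens are not told apart here. The larger contrast is with hydrogen at the same carbon: the series shows a number 15 percentage points lower from compound 1 to compound 3 (beyond the scatter), and compound 2 also stands below compound 1 by a margin beyond the scatter, so in these three compounds either halogen at this carbon goes with less inhibition of growth than hydrogen does. Nothing at hand explains this difference or the lack of one between fluoro and chloro.

Whether the lower inhibition extends to other groups on this aromatic carbon, such as a methyl, a methoxy or an amine, remains open, since the compounds shown carry only hydrogen, fluoro or chloro there. Also open, going by these compounds, is how far these differences hold away from the one concentration tested, and whether the same exchanges behave alike with the chloro group moved elsewhere on the ring.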